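A Branched Amide Chain Enters the Nitrile Series

The source may report more compounds than this note shows. Statements on the series, on what has been measured and on what is new or still open speak of the compounds shown alone.

Going by the values given here, compound 3 `CC/C=C\C(=O)Nc1cc(Nc2ncc(C#N)c(-c3cn(C)c4ccc(F)cc34)n2)c(OC)cc1N(C)CCN(C)C` gives 5880 nM in a functional assay on HepG2 cells (Homo sapiens) for antiproliferative activity, read by MTT assay, with a stated time of 72 h (on this read-out higher numbers stand for weaker inhibition and lower numbers for stronger inhibition), which places it second highest of the three numbers measured so far. Its nearest neighbour is compound 1 `COc1cc(N(C)CCN(C)C)c(NC(=O)/C=C\C(C)C)cc1Nc1nccc(-c2cn(C)c3ccc(F)cc23)n1`, which gives 3920 nM in this assay, a gap within the usual scatter of the assay; furthest from it is compound 2 `C=CC(=O)Nc1cc(Nc2ncc(C#N)c(-c3cn(C)c4ccc(F)cc34)n2)c(OC)cc1N(C)CCN(C)C`, which gives 17500 nM in this assay.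

Compound 4 `COc1cc(N(C)CCN(C)C)c(NC(=O)/C=C\C(C)C)cc1Nc1ncc(C#N)c(-c2cn(C)c3ccc(F)cc23)n1` has not yet been measured. It differs from compound 3 by methyl in place of hydrogen on a saturated chain carbon bound to a double-bonded chain carbon and a saturated chain carbon. Among the compounds with values here, the one measured step that bears on this change is a 3.0-fold lower number from compound 2 to compound 3 (0.47 log units; beyond the scatter), where the amide chain was lengthened from vinyl to but-1-en-1-yl. Compound 4 grows the same chain by one further carbon, now as a branch. Compound 1 already carries the 3-methylbut-1-en-1-yl chain without the nitrile, and its value against that of compound 3 shows the branched and the unbranched chain sitting in the same region of the scale.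

Accordingly the expected step is a 1.3-fold lower number from compound 3 to compound 4 (0.12 log units; within the scatter), no larger than the scatter. Compound 4 is estimated at 4500 nM, within a range of 1800 nM to 11000 nM.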

Compound 4, half-maximal inhibitory concentration: 2840 nM
Compound 4: the middle estimate sits 1.6-fold (0.20 log units) above what was measured, within the range that was stated.
By their numbers in this assay, from the lowest: compounds 4, 1 and 3 (each within the scatter of the next, the first and the last beyond it); then compound 2.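

In this assay, methyl in place of hydrogen on a saturated chain carbon bound to a double-bonded chain carbon and a saturated chain carbon gives a 2.1-fold lower number from compound 3 to compound 4 (0.32 log units; beyond the scatter), so this single added carbon moves the number beyond the scatter. Among the nitrile compounds, the numbers now fall in one direction along the amide chain from vinyl through but-1-en-1-yl to 3-methylbut-1-en-1-yl, with none of the three going against this order, and the whole change of chain amounts to a 6.2-fold lower number from compound 2 to compound 4 (0.79 log units; beyond the scatter). With the 3-methylbut-1-en-1-yl chain held fixed, cyano in place of hydrogen on an aromatic carbon gives a 1.4-fold lower number from compound 1 to compound 4 (0.14 log units; within the scatter), which lies within the scatter, so on this chain the nitrile makes no readable difference.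

Nothing measured alongside these values speaks to what lies behind the steps. On these data alone, it remains open whether the numbers keep falling with a longer chain or with a cyclopropyl group on the double bond of the amide chain, and whether the nitrile makes as little difference when the amide chain is vinyl or but-1-en-1-yl.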